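The source may hold more compounds than are shown below. What is called first, only, known or untested is meant among the compounds shown, and "the series" means these compounds.

For the measured compounds named here, compound 2 `O=C(O)CCc1ccc2[nH]c(-c3ccccc3F)cc2c1` gives 1210 nM in a functional assay on CHO cells for agonist activity at Free fatty acid receptor 1 (Homo sapiens), read by a luciferase reporter, with a stated time of 24 h (a lower number here means that less compound is needed, a higher number that more compound is needed for the effect), the lower of the two numbers so far, though its nearest neighbour compound 1 `O=C(O)CCc1ccc2[nH]c(-c3ccccc3C(F)(F)F)cc2c1` gives 1310 nM, within the scatter. Compound 3 `CCc1ccccc1-c1cc2cc(CCC(=O)O)ccc2[nH]1` carries ethyl in place of fluoro on an aromatic carbon. Going by the values given here, the only measured step at this position, a 1.1-fold lower number from compound 1 to compound 2 (0.03 log units; within the scatter), shows that swapping groups on this aromatic carbon left this assay essentially unchanged. No step beyond the scatter is therefore expected from compound 2 to compound 3, estimated as a 1.0-fold lower number from compound 2 to compound 3 (0.00 log units; within the scatter). Compound 3 is expected at 1200 nM, in the range 500 nM to 3000 nM.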

Compound 3, half-maximal effective concentration: 1800 nM
Compound 3: middle estimate off by 1.5-fold (0.18 log units), on the low side; the range from low to high includes it.
By their numbers in this assay, from the lowest: compounds 2, 1 and 3 (each within the scatter of the next).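

Ethyl adds a substituent without fluorine at this aromatic carbon, and the number in this assay still stays within the scatter of both fluorinated compounds (a 1.5-fold higher number from compound 2 to compound 3 (0.17 log units; within the scatter); a 1.4-fold higher number from compound 1 to compound 3 (0.14 log units; within the scatter)). Across fluoro, trifluoromethyl and ethyl, this position therefore shows no step beyond the scatter. No measurement at hand bears on why these steps are small.

Still open, on these data alone, is whether an amine, a methoxy group, a carboxylic acid or a longer chain on this carbon would give a step beyond the scatter. The same question stands for ethyl on the other carbons of this ring.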